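Butoxy in Place of Benzyl on the Shared Core

A few compounds are considered here, and "the series" means these few. Any claim that something is new, unique, unknown or untested is made for them only; others in the source may bear on it.

Going by the values given here, compound 1 `Nc1nn(C(=O)Nc2ccc(Cc3ccccc3)cc2)c2ccccc12` is the only compound with a number in a functional assay on HT-29 cells (Homo sapiens) for inhibition, read by sulforhodamine B assay, with a stated time of 48 h (on this read-out higher numbers stand for weaker inhibition of growth and lower numbers for stronger inhibition of growth), where compound 1 gives 2390 nM. Compound 2 `COc1ccccc1NC(=O)n1nc(N)c2ccccc21` reaches only a limit of this assay, namely > 100000 nM. Compound 3 `CCCCOc1ccc(NC(=O)n2nc(N)c3ccccc32)cc1` differs from compound 1 by butoxy in place of benzyl on an aromatic carbon, in words: butoxy in place of benzyl on an aromatic carbon. Among the compounds with values here, no measured pair mirrors this change, so the expectation rests on compound 1 alone. In this assay a step of a 2.5-fold higher number from compound 1 to compound 3 (0.40 log units; beyond the scatter) is expected, a loss that lies somewhat beyond the scatter. Compound 3 is therefore expected to give 6000 nM, within 1500 nM to 25000 nM.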

Compound 3, concentration for 50% growth inhibition: 13500 nM
For compound 3 the middle estimate is 2.3-fold (0.35 log units) below the measured one; the measured number falls inside the stated range.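

Butoxy in place of benzyl on this aromatic carbon, para to a large group, gives a 5.6-fold higher number from compound 1 to compound 3 (0.75 log units; beyond the scatter) in this assay and so shows that losing the carbon ring here for an open chain weakens growth inhibition beyond the scatter. Compound 3 nevertheless keeps a number and not a limit, which this read-out can also return: the limit of > 100000 nM in this assay, at which 1 of the 3 values shown sits. The change swaps ring and oxygen at once, so the compounds shown do not tell which of the two matters. A benzyloxy group or a plain pentyl chain at this place would separate them.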